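Acyl aryl variation on the shared core

The compounds below may be only part of what the source reports. "The series", "measured", "known", "first", "only" and "open" are said of these compounds alone.

Measured compounds:
compound 1 `Cc1nc(N(C)C(=O)NC(=O)c2c(F)cccc2F)sc1C(=O)N/N=C/c1ccccc1Cl` — in a functional assay on HepG2 cells (Homo sapiens) for inhibition, read by MTT assay, with a stated time of 72 h (on this read-out higher numbers stand for weaker inhibition and lower numbers for stronger inhibition), compound 1 gives > 100 ug/mL, a limit of the assay rather than a number.
compound 2 `CN(C(=O)NC(=O)c1ccc(Cl)cc1Cl)c1nc(C(F)(F)F)c(C(=O)N/N=C/c2ccccc2C(F)(F)F)s1` — compound 2 gives 10.7 ug/mL.
compound 3 `CN(C(=O)NC(=O)c1c(Cl)cccc1Cl)c1nc(C(F)(F)F)c(C(=O)N/N=C/c2ccccc2C(F)(F)F)s1` — compound 3 gives 8.95 ug/mL.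

Compound 3 holds the lowest of the two numbers; its nearest neighbour is compound 2, and the step of a 1.2-fold lower number from compound 2 to compound 3 (0.08 log units; within the scatter) lies within the scatter. Compound 1 sits at the limit of > 100 ug/mL in this assay, at which 1 of the 3 values shown sits.

Compound 4 `CN(C(=O)NC(=O)c1ccc(C(F)(F)F)cc1)c1nc(C(F)(F)F)c(C(=O)N/N=C/c2ccccc2C(F)(F)F)s1` carries 4-(trifluoromethyl)phenyl in place of 2,6-dichlorophenyl on a carbonyl carbon. For the measured compounds named here, the only measured step on this carbonyl carbon is a 1.2-fold lower number from compound 2 to compound 3 (0.08 log units; within the scatter), which was within the scatter; a trifluoromethyl at the 4-position has no measured precedent here. The expected step of a 1.3-fold higher number from compound 3 to compound 4 (0.13 log units; within the scatter) is therefore none beyond the scatter. Compound 4 is estimated at 12 ug/mL, with a range of 5 ug/mL to 30 ug/mL.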

Compound 4, half-maximal inhibitory concentration: 3.64 ug/mL
The estimate for compound 4 lay 3.3-fold (0.52 log units) above the measured number; measured number outside the range, below it.
By their numbers in this assay, from the lowest: compound 4; then compounds 3 and 2 (each within the scatter of the next). At a limit, above all of these: compound 1.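

In this assay, for the compounds shown here, 4-(trifluoromethyl)phenyl in place of 2,6-dichlorophenyl gives a 2.5-fold lower number from compound 3 to compound 4 (0.39 log units; beyond the scatter) on this carbonyl carbon, the first step at this position beyond the scatter. In place of 2,4-dichlorophenyl the same group gives a 2.9-fold lower number from compound 2 to compound 4 (0.47 log units; beyond the scatter) as well, while those two dichlorophenyl compounds stand within the scatter of each other. The number at this position therefore responds to the aryl group, though only modestly in these steps.

Going by these compounds, whether the lower number follows the trifluoromethyl itself or its place on the ring stays open, as does the outcome with an amine or a carboxylic acid on that ring. Nothing measured here accounts for these steps.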